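Notes on compound 1 and its amide variant compound 3

This account rests on a few compounds, and the source may have more. Where it says the series, first, only, none or still open, it means among the compounds named here.

compound 1 `COc1ccc(C(=O)/C=C/c2ccc(C(=O)NCc3ccccc3)cc2)c(O)c1` — > 100000 nM
compound 2 `COc1ccc(C(=O)/C=C/c2cc(OC)c(OC)cc2OC)c(O)c1` — > 100000 nM

Compound 1 `COc1ccc(C(=O)/C=C/c2ccc(C(=O)NCc3ccccc3)cc2)c(O)c1` is the reference point of this set. In an ADME assay on SH-SY5Y cells (Homo sapiens) for cytotoxicity, read by MTT assay, with a stated time of 48 h (a higher number here means a weaker inhibitor, a lower number a stronger inhibitor), compound 1 gives > 100000 nM, which is a limit of the assay and not a number. Compound 2 `COc1ccc(C(=O)/C=C/c2cc(OC)c(OC)cc2OC)c(O)c1` in this assay gives > 100000 nM, again a limit rather than a number. Compound 1 therefore stands at the limit, and the only other compound shown stands there too (the limit of > 100000 nM in this assay, at which 2 of the 2 values shown sit); no step between two measured numbers can be drawn from this.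

Compound 3 `COc1ccc(C(=O)/C=C/c2ccc(C(=O)Nc3ccc(C)cc3C)cc2)c(O)c1` has not yet been measured. It differs from compound 1 in one place (2,4-dimethylphenyl in place of benzyl on an amide-type nitrogen). Since both values shown sit at the limit (the limit of > 100000 nM in this assay, at which 2 of the 2 values shown sit), there is no basis for expecting a step beyond the scatter in either direction from compound 1 to compound 3, and a return to the limit is the most likely outcome. Compound 3 is expected to give 100000 nM in this assay, with an estimated range from 40000 nM to 250000 nM. The estimated step of a number no higher from compound 1 to compound 3 (the limit leaves the size open) is expected to be none beyond the scatter.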

Compound 3, half-maximal inhibitory concentration: > 100000 nM
Compound 3 ended at the assay's limit; the forecaster's own chance of this, stated with the estimate: 80%; the middle value lies on the limit itself.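

In this assay compound 3 gives > 100000 nM, a limit of the assay and not a number, so no new step from compound 1 to compound 3 can be read: the limit of > 100000 nM in this assay, at which 3 of the 3 values shown sit.

The compounds shown leave open what actual numbers compound 1 and compound 3 would give, and whether any group on the amide-type nitrogen would bring a readable value.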